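This account rests on a few compounds, and the source may have more. Where it says the series, first, only, none or still open, it means among the compounds named here.

Measured so far in a functional assay on CAKI-1 cells (Homo sapiens) for antiproliferative activity; a higher number here means a weaker inhibitor of growth, a lower number a stronger inhibitor of growth
Compound 1 `Cc1ccnc2nc(-c3cccc(Cl)c3)cc(O)c12` gives 33.1 nM
Compound 2 `Cc1cnc2[nH]c(-c3cccc(Cl)c3)cc(=O)c2c1` gives 42.7 nM

Compound 2 lies within the scatter of compound 1, so the two values set no order. Going by these compounds, compound 3 `Cc1cnc2[nH]c(-c3cccc(F)c3)cc(=O)c2c1` has fluoro in place of chloro on an aromatic carbon of compound 2 fluoro in place of chloro on an aromatic carbon and remains untested. Going by the values given here, no measured pair covers this change, so its size rests on the structural change alone. In this assay no step beyond the scatter is expected, with a slight lean toward a higher number. The estimated move a 1.2-fold higher number from compound 2 to compound 3 (0.07 log units; within the scatter) stays within the scatter. Compound 3 is expected at 50 nM (range from 16 nM to 160 nM).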

Compound 3, concentration for 50% growth inhibition: 28.2 nM
The estimate for compound 3 lay 1.8-fold (0.25 log units) above the measured number, and the stated range covers the measured number.
By their numbers in this assay, from the lowest: compounds 3, 1 and 2 (each within the scatter of the next).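

In this assay, fluoro in place of chloro on an aromatic carbon, meta to a large group, gives a 1.5-fold lower number from compound 2 to compound 3 (0.18 log units; within the scatter) and so sets no order between the two halogens at this position. The number stays close to that of compound 2 when a chlorine gives way to a fluorine. No measurement here offers a reason for this closeness.

Going by these compounds, whether a methoxy group, an amine or a carboxylic acid at this place would bring a step beyond the scatter remains open. So does the effect of removing the halogen altogether.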